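Replacing the Methoxyphenyl Group of Compound 3

A few compounds are considered here, and "the series" means these few. Any claim that something is new, unique, unknown or untested is made for them only; others in the source may bear on it.

Of the compounds shown here, three sharing one core have been tested in a functional assay on A549 cells (Homo sapiens) for antiproliferative activity, read by MTT assay, with a stated time of 72 h; a higher number here means a weaker inhibitor, a lower number a stronger inhibitor. Compound 1 `O=C(N/N=C/c1ccc([N+](=O)[O-])cc1)Nc1ccc(Oc2ccnc3[nH]ccc23)cc1` gives 2100 nM, and compound 3 `COc1ccc(/C=N/NC(=O)Nc2ccc(Oc3ccnc4[nH]ccc34)cc2)cc1` gives 4300 nM, the higher of the two numbers and so the weaker result. Compound 2 `O=C(N/N=C/c1cccc(Cl)c1Cl)Nc1ccc(Oc2ccnc3[nH]ccc23)cc1` is recorded as "not active" (no number reported), which gives no number to compare but shows that a change in this part of the structure can leave no measurable activity.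

Compound 4 `CN(C)CCCn1cccc1/C=N/NC(=O)Nc1ccc(Oc2ccnc3[nH]ccc23)cc1` keeps the core and makes a larger change, with 1-(3-(dimethylamino)propyl)-1H-pyrrol-2-yl in place of 4-methoxyphenyl on a carbon with a double bond to nitrogen. Going by the values given here, only one measured step bears on this: a 2.0-fold higher number from compound 1 to compound 3 (0.31 log units; beyond the scatter), a modest change made by putting methoxy in place of nitro on an aromatic carbon. That step keeps the six-membered aromatic ring, whereas compound 4 loses it, so the step is only a loose guide. Among the compounds with values here, no tested compound carries a five-membered aromatic ring or this chain, so the direction is uncertain. The expected change, of similar modest size, is a 1.7-fold lower number from compound 3 to compound 4 (0.24 log units; within the scatter). For compound 4 the estimated value is 2500 nM, with an expected range from 600 nM to 10000 nM.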

Compound 4, half-maximal inhibitory concentration: 2660 nM
Compound 4: the middle estimate sits 1.1-fold (0.03 log units) below what was measured; low and high end bracket the measured number.
By their numbers in this assay, from the lowest: compounds 1, 4 and 3 (each within the scatter of the next, the first and the last beyond it).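

In this assay, going by these compounds alone, this position takes a much larger replacement than the earlier compounds showed: putting 1-(3-(dimethylamino)propyl)-1H-pyrrol-2-yl in place of 4-methoxyphenyl gives a 1.6-fold lower number from compound 3 to compound 4 (0.21 log units; within the scatter) and in place of 4-nitrophenyl gives a 1.3-fold higher number from compound 1 to compound 4 (0.10 log units; within the scatter) with both steps inside the usual scatter. Within the data shown here, until now every group tested here was a six-membered aromatic ring of carbon only, so compound 4 is the first to show that a five-membered aromatic ring with 1 hetero atom, carrying a chain that ends in dimethylamino, still gives a measurable number, unlike compound 2, which is recorded as not active. Nothing available explains why compound 4 reads so close to both neighbours.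

The compounds shown leave open whether the five-membered aromatic ring or the chain accounts for this result, and a plain 1H-pyrrol-2-yl with no chain would separate the two. On these data alone, it is also open how the chain itself matters, which a shorter propyl-free ethyl link, a morpholine or a carboxylic acid at the chain end could test.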